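Methoxycarbonyl to acetoxymethyl: a step in the series

The source may report more compounds than this note shows. Statements on the series, on what has been measured and on what is new or still open speak of the compounds shown alone.

In a functional assay on A549 cells (Homo sapiens) for cytotoxicity, read by sulforhodamine B assay, with a stated time of 3 days (on this read-out lower numbers stand for an effect already at smaller amounts and higher numbers for an effect only at larger amounts of compound), compound 2 (`COC(=O)c1c(C)coc1-c1ccc2c(c1OC)CCCC2(C)C`) gives 61 uM and compound 3 (`CCc1cccc2c(O)c(-c3occ(C)c3C(=O)O)ccc12`) gives 35.8 uM, so the two sit together at the upper end, within the scatter of each other. Compound 1 (`CCOCc1c(C)coc1-c1ccc2c(c1OC)CCCC2(C)C`) gives 22.9 uM. Compound 4 (`COc1c(-c2occ(C)c2COC(C)=O)ccc2c1CCCC2(C)C`) carries acetoxymethyl in place of methoxycarbonyl on an aromatic carbon. For the measured compounds named here, the only measured step at this place is a 2.7-fold higher number from compound 1 to compound 2 (0.43 log units; beyond the scatter), modest and beyond the scatter. Acetoxymethyl resembles the ethoxymethyl of compound 1 in its link to the aromatic carbon, so part of that step is expected to reverse, towards a lower number. The expected change is a 1.7-fold lower number from compound 2 to compound 4 (0.24 log units; within the scatter). For compound 4 the estimate is 35 uM, with an expected range of 14 uM to 80 uM.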

Compound 4, concentration for half-maximal effect: 28.7 uM
Beside the measured number, compound 4's estimate is 1.2-fold (0.09 log units) above it; the range from low to high includes it.
By their numbers in this assay, from the lowest: compounds 1, 4, 3 and 2 (each within the scatter of the next, the first and the last beyond it).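

In this assay, acetoxymethyl gives a 2.1-fold lower number from compound 2 to compound 4 (0.33 log units; beyond the scatter) and so provides a second step at this position that is beyond the scatter, this time with the ester link reversed. Acetyl in place of ethyl on the oxygen gives a 1.3-fold higher number from compound 1 to compound 4 (0.10 log units; within the scatter) and stays within the scatter, so the two side chains joined through a saturated carbon are not told apart here, while both stand apart from methoxycarbonyl. Nothing at hand explains this.

Open, going by these compounds, is how a hydroxymethyl, an aminomethyl or a longer chain on this aromatic carbon would read out. Also open, on these data alone, is whether any of these steps holds on a different core.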